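A few compounds are considered here, and "the series" means these few. Any claim that something is new, unique, unknown or untested is made for them only; others in the source may bear on it.

In an assay on isolated protein for binding affinity to melatonin receptor type 1A (Homo sapiens) (a higher number here means a weaker inhibitor, a lower number a stronger inhibitor), compound 1 `COc1cccc(Oc2ccc(NC(C)=O)cc2)c1` gives 84 nM. Compound 2 `CCC(=O)Nc1ccc(Oc2cccc(OC)c2)cc1` gives 300 nM in this assay, and the change between them, (methyl in place of hydrogen on a saturated chain carbon bound to a carbonyl carbon), produced a 3.6-fold higher number from compound 1 to compound 2 (0.55 log units; beyond the scatter). Compound 3 `COc1cccc(N(C)c2ccc(NC(C)=O)cc2)c1` gives 0.05 nM, the lowest of the three numbers. The difference between the core of compound 1 and the core of compound 3 is not broken down here.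

Compound 4 `CCC(=O)Nc1ccc(N(C)c2cccc(OC)c2)cc1` has not yet been measured in this assay. It differs from compound 3 by methyl in place of hydrogen on a saturated chain carbon bound to a carbonyl carbon, the same change that separates compound 1 and compound 2, at a place described in the same words. Within the data shown here, the only earlier example of this change gave a 3.6-fold higher number from compound 1 to compound 2 (0.55 log units; beyond the scatter), so a weakening of similar size is expected here, a 4.0-fold higher number from compound 3 to compound 4 (0.60 log units; beyond the scatter), although a single precedent is a thin basis. Compound 4 is therefore estimated at 0.2 nM, with a likely range from 0.05 nM to 1 nM.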

Compound 4, inhibition constant: 1 nM
Compound 4: the middle estimate sits 5.0-fold (0.70 log units) below what was measured, and the stated range covers the measured number.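

Replacing acetamido with propanoylamino gave a 20-fold higher number from compound 3 to compound 4 (1.30 log units; beyond the scatter) in this assay. The direction of the change carried over from one core to the other, but its size did not: the same change on two cores in this assay, a 3.6-fold higher number (0.55 log units; beyond the scatter) from compound 1 to compound 2 and a 20-fold higher number (1.30 log units; beyond the scatter) from compound 3 to compound 4, 5.6-fold (0.75 log units) apart, beyond the scatter of two such steps

With only these two pairs, the earlier step points the right way but does not fix how large the step will be on another core, and these data do not show what makes the two cores respond differently.

From the compounds shown here alone, whether a longer chain, such as butanoyl, or a branched one, such as isobutyryl, would weaken binding further on either core remains open. So does whether the gap between the two cores would widen with such groups.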